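The source may hold more compounds than are shown below. What is called first, only, known or untested is meant among the compounds shown, and "the series" means these compounds.

Measured compounds:
compound 1 `COc1cc(-c2cc(/C=C/C(=O)c3ccc(Cl)c(Cl)c3)[nH]n2)cc(OC)c1OC`; in a functional assay on UO-31 cells (Homo sapiens) for cytotoxicity, read by sulforhodamine B assay, with a stated time of 48 h, tested at 1 uM (on this read-out higher numbers stand for a weaker effect at the one concentration tested and lower numbers for a stronger effect), compound 1 gives 81%.
compound 2 `COc1ccc(-c2cc(/C=C/C(=O)c3cc(OC)c(OC)c(OC)c3)[nH]n2)cc1OC`; in this assay compound 2 gives 67%.

Compound 1 stands highest of these two numbers, and compound 2 lies lower by a gap beyond the usual scatter. Compound 3 `COc1cc(-c2cc(/C=C/C(=O)c3ccc(F)c(F)c3)[nH]n2)cc(OC)c1OC` differs from compound 1 in a single place: 3,4-difluorophenyl in place of 3,4-dichlorophenyl on a carbonyl carbon. For the measured compounds named here, no measured pair shows this change, so the expected step is small: a number 4 percentage points higher from compound 1 to compound 3 (within the scatter), a shift not beyond the scatter, anchored on compound 1 giving 81%. Compound 3 is therefore estimated at 85%, expected to fall between 70% and 100%.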

Compound 3, a percentage reported as activity, at one concentration (the size of the read-out at that concentration, not a potency): 84%
Beside the measured number, compound 3's estimate is 1 percentage points above it, and the stated range covers the measured number.
By their numbers in this assay, from the lowest: compound 2; then compounds 1 and 3 (each within the scatter of the next).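

In this assay, 3,4-difluorophenyl in place of 3,4-dichlorophenyl on the carbonyl carbon gives a number 3 percentage points higher from compound 1 to compound 3 (within the scatter). For the compounds shown here, this is the first single-place comparison in the set, and it shows that these two halogen pairs cannot be told apart at this position. Nothing available explains this result.

Going by these compounds, what remains open is whether a different kind of group on this phenyl ring, such as a dimethylamino group or a carboxylic acid, would shift the number beyond the scatter. On these data alone, whether a single halogen would behave like these pairs also stays unknown.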